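The source may hold more compounds than are shown below. What is called first, only, known or untested is meant among the compounds shown, and "the series" means these compounds.

Measured in an assay on isolated protein for inhibition of leukotriene B4 receptor 1 (Homo sapiens), tested at 10 uM; on this read-out higher numbers stand for more inhibition at the one concentration tested (going by the name of the read-out) and lower numbers for less inhibition:

Compound 1 `CCc1cc(C(C)=O)c(O)cc1OCCCCCC(C)(C)C(=O)O` gives 104%.
Compound 2 `CCc1cc(C(C)=O)c(O)cc1OCCCCCCSC` gives 71%.

Compound 2 stands lowest of the two numbers shown. Going by the values given here, its only neighbour is compound 1, and the step of a number 33 percentage points lower from compound 1 to compound 2 (beyond the scatter) is beyond the scatter, so the two compounds are clearly separated on this read-out.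

Compound 3 `CCc1cc(C(C)=O)c(O)cc1OCCCCCCC(=O)O` differs from compound 2 in one place: carboxy in place of methylsulfanyl on a saturated chain carbon, six bonds along the chain from an oxygen on an aromatic ring. Among the compounds with values here, the single measured step that bears on this change is a number 33 percentage points lower from compound 1 to compound 2 (beyond the scatter), in which a carboxy-bearing group gave way to the methylsulfanyl group and the number fell sharply. The step to compound 3 runs the other way, restoring a carboxy at the chain end, though compound 3 does not carry the 1-carboxy-1-methylethyl group of compound 1. On that basis the number is expected to rise again in this assay, recovering most of what compound 2 lost, with an expected step of a number 24 percentage points higher from compound 2 to compound 3 (beyond the scatter). Compound 3 is therefore estimated at 95%, in a range from 75% to 110%.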

Compound 3, a percentage reported as inhibition, at one concentration (the size of the read-out at that concentration, not a potency): 87%
Compound 3: the middle estimate sits 8 percentage points above what was measured; measured number inside the range.
By their numbers in this assay, from the lowest: compound 2; then compound 3; then compound 1.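

In this assay, the change from methylsulfanyl to carboxy at the chain end gives a number 16 percentage points higher from compound 2 to compound 3 (beyond the scatter), so a carboxy group on this chain carbon, without the branching of compound 1, already lifts the number beyond the scatter. The carboxy group alone does not close the whole gap, however: carboxymethyl in place of 1-carboxy-1-methylethyl gives a number 17 percentage points lower from compound 1 to compound 3 (beyond the scatter), which separates the branched chain end from the unbranched one and shows that the number here responds to more than the presence of the carboxy group. No measurement at hand explains either step.

The compounds shown leave open whether an amine, a primary amide or a methyl ester at the chain end would hold the number near that of compound 3 or fall toward that of compound 2. They also leave open how a longer or shorter chain ending in a carboxylic acid, or a single methyl group on the chain carbon that bears the carboxy group, would read in this assay, where all these numbers come from one concentration and are not potencies.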